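Chloro to methyl on the aromatic carbon: series notes

The compounds below may be only part of what the source reports. "The series", "measured", "known", "first", "only" and "open" are said of these compounds alone.

Two members of the series have so far been run in a functional assay on the whole organism (strain Swiss albino) for inhibition, with Mus musculus as the target, in the formalin test, with a stated time of 30 min, at a dose of 100 mg/kg by the intraperitoneal route; a higher number here means more inhibition at the dose given (going by the name of the read-out), a lower number less inhibition. Compound 1 `Nn1c(CCc2ccc(O)cc2)nnc1SCC(=O)N1N=C(c2cccs2)CC1c1ccccc1` gives 79.2% in this assay. Compound 2 `Nn1c(CCc2ccc(O)cc2)nnc1SCC(=O)N1N=C(c2cccs2)CC1c1ccc(Cl)cc1`, carrying a chloro in place of hydrogen on an aromatic carbon, gives 72.1% in this assay. Going by the values given here, the only computed step is a number 7.1 percentage points lower from compound 1 to compound 2 (within the scatter), which lies within the scatter, so compound 2 holds the lower of the two figures without being separable from compound 1. Compound 3 `Cc1ccc(C2CC(c3cccs3)=NN2C(=O)CSc2nnc(CCc3ccc(O)cc3)n2N)cc1` has not yet been measured; it differs from compound 2 by methyl in place of chloro on an aromatic carbon. Among the compounds with values here, the one step that bears on this change, a number 7.1 percentage points lower from compound 1 to compound 2 (within the scatter), concerned the same aromatic carbon and stayed within the scatter, so a second swap at that carbon is expected to move this assay by nothing beyond the scatter. The expected step is a number 2.9 percentage points higher from compound 2 to compound 3 (within the scatter). Compound 3 is therefore estimated at 75% in this assay, with a range from 63% to 86%.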

Compound 3, a percentage reported as inhibition, in the whole organism at one dose (the size of the read-out at that dose, not a potency): 42.5%
Compound 3: middle estimate off by 32.5 percentage points, on the high side; measured number outside the range, below it.
By their numbers in this assay, from the lowest: compound 3; then compounds 2 and 1 (each within the scatter of the next).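

In this assay this aromatic carbon proves sensitive to what it carries: the swap of chloro for methyl gives a number 29.6 percentage points lower from compound 2 to compound 3 (beyond the scatter) and, set against the hydrogen of the parent, methyl gives a number 36.7 percentage points lower from compound 1 to compound 3 (beyond the scatter) here. Hydrogen and chloro remain inseparable at this position, so compound 3 alone stands apart, and the earlier step gave no sign of this, since it stayed within the scatter. Nothing at hand explains why a swap of one heavy atom for another, with no change in hydrogen-bond donors, acceptors or charge, costs this much.

On these data alone, whether the loss belongs to methyl alone or extends to other groups on this carbon stays open, and methoxy, fluoro, an amine or a longer chain such as ethyl would bear on that. All three figures are also single-dose read-outs, so they leave any difference in potency undefined.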